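Homologating the acid chain on two related cores

A few compounds are considered here, and "the series" means these few. Any claim that something is new, unique, unknown or untested is made for them only; others in the source may bear on it.

Compound 1 `CCCc1c(COc2ccc(C(=O)CCC(=O)O)cc2)ccc(C(C)=O)c1O` and compound 2 `CCCc1c(COc2ccc(C(=O)CCCC(=O)O)cc2)ccc(C(C)=O)c1O` share one core. In an in vivo functional assay on the whole organism (Rattus norvegicus) with cysteinyl leukotriene receptor (Homo sapiens) as the target (a higher number here means that more compound is needed for the effect, a lower number that less compound is needed), compound 1 gives 18.2 mg/kg, and compound 2 gives 9.5 mg/kg. The change between them is carboxymethyl in place of carboxy on a saturated chain carbon, two bonds along the chain from a carbonyl carbon and it made a 1.9-fold lower number from compound 1 to compound 2 (0.28 log units; within the scatter).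

Compound 3 `CCCc1c(COc2ccc(Cc3nnn(CCCC(=O)O)n3)cc2)ccc(C(C)=O)c1O` carries a different core; the difference between the two cores is not broken down here. In this assay compound 3 gives 19.6 mg/kg, a number close to that of compound 1 and beyond the scatter from that of compound 2.

Compound 4 `CCCc1c(COc2ccc(Cc3nnn(CCCCC(=O)O)n3)cc2)ccc(C(C)=O)c1O` has not been measured. It differs from compound 3 by carboxymethyl in place of carboxy on a saturated chain carbon, three bonds along the chain from an aromatic nitrogen. This is the same kind of change as that from compound 1 to compound 2, though the place differs: there the chain carbon lies two bonds along the chain from a carbonyl carbon, here three bonds along the chain from an aromatic nitrogen. Within the data shown here, because the earlier step was a 1.9-fold lower number from compound 1 to compound 2 (0.28 log units; within the scatter), a step of similar size is expected for compound 4 in this assay, namely a 1.6-fold lower number from compound 3 to compound 4 (0.21 log units; within the scatter), although the single earlier step lies within the scatter. Compound 4 is therefore estimated at 12 mg/kg, with a range from 6 mg/kg to 25 mg/kg.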

Compound 4, dose for half-maximal effect: 7 mg/kg
Compound 4: the middle estimate sits 1.7-fold (0.23 log units) above what was measured; low and high end bracket the measured number.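

In this assay, the same change on the second core, carboxymethyl in place of carboxy, gave a 2.8-fold lower number from compound 3 to compound 4 (0.45 log units; beyond the scatter), so the step is larger than the usual scatter on this core, which the earlier step on the first core was not. Set side by side, the two steps run the same way and cannot be told apart in size, so the change carried over from one core to the other as far as these compounds can show: the same change on two cores in this assay, a 1.9-fold lower number (0.28 log units; within the scatter) from compound 1 to compound 2 and a 2.8-fold lower number (0.45 log units; beyond the scatter) from compound 3 to compound 4, 1.5-fold (0.16 log units) apart, within the scatter of two such steps This rests on only two pairs of compounds and a single whole-animal read-out, so it shows neither that the change would carry over to any further core nor why the number falls.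

The compounds shown stop at the 4-carboxybutyl chain on the second core, so it remains open whether a longer chain would lower the number further or reverse the trend. Also open, as far as these compounds go, is how an amine or an amide in place of the carboxylic acid would behave on either core.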